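The source may report more compounds than this note shows. Statements on the series, on what has been measured and on what is new or still open speak of the compounds shown alone.

Compounds measured in a functional assay on QGY7701 cells (Homo sapiens) for cytotoxicity, read by MTT assay, with a stated time of 24 h; a higher number here means a weaker inhibitor, a lower number a stronger inhibitor:
Compound 1 `C=CC1=C(C(=O)NCCC)C(c2ccc(F)cc2)OC1` — in this assay compound 1 gives > 100000 nM, a limit of the assay.
Compound 2 `C=CC1=C(C(=O)NCc2ccccc2)C(c2ccc(OC)cc2)OC1` — compound 2 gives > 100000 nM, again a limit.
Compound 3 `C=CC1=C(C(=O)O)C(c2ccc(F)cc2)OC1` — compound 3 gives > 100000 nM, also a limit.

Compound 3 therefore stands at the limit, and every value shown sits at the limit of > 100000 nM in this assay, at which 3 of the 3 values shown sit. Among the measured compounds shown here, the one step that can be drawn, a step that the two limits leave unreadable from compound 1 to compound 3, is not readable. Compound 4 `C=CC1=C(C(=O)O)C(c2ccc(OC)cc2)OC1` differs from compound 3 by methoxy in place of fluoro on an aromatic carbon. For the measured compounds named here, compound 2 carries the methoxy group and sits at the same limit, so no measured step points to a change in this assay beyond the scatter. Compound 4 is expected to give about 150000 nM, with a range from 60000 nM to 400000 nM. The estimated step from compound 3 to compound 4 is a step that the limit leaves unreadable from compound 3 to compound 4.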

Compound 4, half-maximal inhibitory concentration: > 100000 nM
Compound 4 was reported as a limit; the forecaster's own chance of this, stated with the estimate: 85%; the middle value is on the limit's open side.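

No step from compound 2 or compound 3 to compound 4 can be read, because all of these values stand at one limit: the limit of > 100000 nM in this assay, at which 4 of the 4 values shown sit.

The compounds shown leave open how any of these changes to the shared core would register in this assay.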